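Replacing (4-Methylpiperazin-1-yl)methyl with 1-Methylpiperidin-4-yl

The source may hold more compounds than are shown below. What is called first, only, known or untested is meant among the compounds shown, and "the series" means these compounds.

Compound 1 `COc1cc(C)c(S(=O)(=O)N(C)CCOCC(=O)N2CCN(CCCN(C)C)CC2)c(C)c1` gives 7.9
Compound 2 `COc1cc(C)c(S(=O)(=O)N(C)CCOCC(=O)N2CCC(CN3CCN(C)CC3)CC2)c(C)c1` gives 8.1

In a functional assay on Umbilical vein for antagonist activity at B1 bradykinin receptor (Homo sapiens), using Schild analysis, with a stated time of 30 min (a lower number here means a less potent compound, a higher number a more potent compound, by a factor of ten per unit of this negative logarithm), compound 2 shows the higher of the two numbers, yet compound 1 sits within the usual scatter of it, so the two cannot be ranked. Compound 3 `COc1cc(C)c(S(=O)(=O)N(C)CCOCC(=O)N2CCC(C3CCN(C)CC3)CC2)c(C)c1` is not yet measured. It differs from compound 2 in one place: 1-methylpiperidin-4-yl in place of (4-methylpiperazin-1-yl)methyl on a saturated ring carbon. Among the measured compounds shown here, no measured pair shows a change of this kind, so its effect is unknown. The expectation is a small step, a number 0.20 log units lower from compound 2 to compound 3 (within the scatter), not beyond the scatter. Compound 3 is therefore estimated at 7.9, with a range from 7.3 to 8.5.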

Compound 3, negative logarithm of the antagonist equilibrium constant: 9
Compound 3: the middle estimate sits 1.10 log units below what was measured; measured number above the stated range.
By their numbers in this assay, from the lowest: compounds 1 and 2 (each within the scatter of the next); then compound 3.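

In this assay, the saturated ring carbon of the six-membered ring with 1 nitrogen proves sensitive to what it carries: 1-methylpiperidin-4-yl in place of (4-methylpiperazin-1-yl)methyl gives a number 0.90 log units higher from compound 2 to compound 3 (beyond the scatter). The entering group has one ring hetero atom rather than two and fewer heavy atoms, so this single step cannot separate those differences. Nothing available explains the step. Open, from the compounds shown here alone, is whether 4-methylpiperazin-1-yl attached directly to this carbon would match compound 3, and whether 1-ethylpiperidin-4-yl or unsubstituted piperidin-4-yl would keep its number.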